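This account rests on a few compounds, and the source may have more. Where it says the series, first, only, none or still open, it means among the compounds named here.

Compound 1 `CCCCCn1c(-c2ccco2)nc2c(N)ccnc21` gives > 200000 nM in an assay on isolated protein for inhibition of high affinity 3',5'-cyclic-AMP phosphodiesterase 7A (Homo sapiens), read by cAMP accumulation, with a stated time of 20 min (on this read-out higher numbers stand for weaker inhibition and lower numbers for stronger inhibition), a limit of the assay.
Compound 2 `CCCCCn1c(-c2ccco2)nc2c(NCc3ccccc3)ccnc21` gives > 200000 nM in this assay, likewise a limit.
Compound 3 `CCCCCn1c(-c2ccco2)nc2c(NCCOC)ccnc21` gives > 200000 nM in this assay, again a limit.

Compound 3 therefore stands only at a limit, as do the other two, and the limit of > 200000 nM in this assay, at which 3 of the 3 values shown sit, is the whole picture. The three measured steps, a step that the two limits leave unreadable from compound 1 to compound 2, a step that the two limits leave unreadable from compound 1 to compound 3 and a step that the two limits leave unreadable from compound 2 to compound 3, are all unreadable, and none of them touches the place changed in compound 4 `COCCNc1ccnc2c1nc(-c1ccco1)n2C1CCCC1`, namely (cyclopentyl in place of pentyl on an aromatic nitrogen). Among the compounds with values here, no measured step therefore bears on this change, and no direction can be expected beyond the scatter. Compound 4 is expected to sit at 200000 nM, within 50000 nM to 600000 nM, most likely again reported only as a limit, which is the step of a number no higher from compound 3 to compound 4 (the limit leaves the size open).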

Compound 4, half-maximal inhibitory concentration: 119000 nM
Compound 4: middle estimate off by 1.7-fold (0.23 log units), on the high side, and the stated range covers the measured number.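

Within the data shown here, on the aromatic nitrogen, cyclopentyl in place of pentyl gives the only value in this assay that is a number and not a limit, so this position offers the first readable result: the limit of > 200000 nM in this assay, at which 3 of the 4 values shown sit. The change is an at least 1.6-fold lower number from compound 3 to compound 4 (0.22 log units; that floor lies within the scatter) and so does not establish a real gain, as compound 3 stands at a limit. The compounds shown leave open whether cyclobutyl, cyclohexyl or a longer chain on that nitrogen would lower the number further. They also leave open whether a carboxylic acid on the 2-methoxyethyl chain would change it.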